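This account rests on a few compounds, and the source may have more. Where it says the series, first, only, none or still open, it means among the compounds named here.

Of the compounds shown here, three with a shared core have been tested in an assay on HL-60 cells for agonist activity at N-formyl peptide receptor 3 (Homo sapiens), read by calcium flux (a higher number here means that more compound is needed for the effect, a lower number that less compound is needed), and all three reached only the limit of the method rather than a measured number. Compound 1 `COc1cccc(Cc2cc(-c3ccccc3)nn(CC(=O)Nc3ccc(Br)cc3)c2=O)c1` gives a limit of > 50000 nM in this assay. Compound 2 `COc1cccc(Cc2cc(-c3cccs3)nn(CC(=O)Nc3ccc(F)cc3)c2=O)c1` likewise gives a limit of > 50000 nM in this assay. Compound 3 `Cc1cc(Cc2cccc(F)c2)c(=O)n(CC(=O)Nc2ccc(Br)cc2)n1`, the starting point here, also gives a limit of > 50000 nM in this assay. So compound 3 stands nowhere in particular among the numbers shown: every value is the same ceiling, as the limit of > 50000 nM in this assay, at which 3 of the 3 values shown sit, records, and no ordering of the three can be drawn from them.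

Compound 4 `Cc1cc(Cc2cccc3ccccc23)c(=O)n(CC(=O)Nc2ccc(Br)cc2)n1` differs from compound 3 in one place: naphthalen-1-yl in place of 3-fluorophenyl on a saturated chain carbon bound to an aromatic carbon. Nothing measured among these compounds speaks for or against this change, since no pair of measured compounds differs in a single place, and every measured value is a limit. The expectation for compound 4 is therefore simply that it behaves like compound 3 and again reaches only the limit of this assay, which means an expected step that the limit leaves unreadable from compound 3 to compound 4 from compound 3 to compound 4, in neither direction beyond the scatter. The estimated value for compound 4 in this assay is 60000 nM, with a range from 15000 nM to 200000 nM.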

Compound 4, half-maximal effective concentration: > 50000 nM
Compound 4: a limit, no number (the forecaster's own chance of this, stated with the estimate: 80%); the middle value does not contradict the limit.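

In this assay compound 4 gives > 50000 nM, which is a limit and not a number. Compound 3 also gives a limit, so no step can be read between compound 3 and compound 4, and the set shares one ceiling: the limit of > 50000 nM in this assay, at which 4 of the 4 values shown sit.

The compounds shown leave open whether any change to the shared core would give a measurable number in this assay, and how far apart these compounds really lie.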